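From phenyl to 4-bromophenyl on compound 2

The source may report more compounds than this note shows. Statements on the series, on what has been measured and on what is new or still open speak of the compounds shown alone.

Three related compounds have been tested in a functional assay on MOLT-4 cells (Homo sapiens) for antiproliferative activity, read by cell counting, with a stated time of 2 days; on this read-out lower numbers stand for stronger inhibition and higher numbers for weaker inhibition. Compound 2 `COc1ccc(Nc2nc(N)c(C(=O)c3ccccc3)s2)cc1` gives 230 nM, the lower of the two true numbers obtained so far. Compound 1 `COc1ccc(C(=O)c2sc(Nc3ccccc3)nc2N)cc1OC` gives 5500 nM, a clearly higher number, though it differs from compound 2 in more than one place. Compound 3 `Nc1nc(Nc2ccc(Cl)cc2)sc1C(=O)c1ccccc1` gives > 10000 nM, which is a limit of the assay.

The next molecule is compound 4 `COc1ccc(Nc2nc(N)c(C(=O)c3ccc(Br)cc3)s2)cc1`. It matches compound 2 except that a phenyl becomes 4-bromophenyl, with bromo in place of hydrogen on an aromatic carbon.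

Among the measured compounds shown here, only one measured step changes a single place: an at least 43-fold higher number from compound 2 to compound 3 (1.63 log units; beyond the scatter). That large step comes from chloro in place of methoxy, so one small swap in this series can matter a great deal. It is weak guidance here, however, since it lies elsewhere in the molecule and replaces a group rather than a hydrogen. For the measured compounds named here, no measured step touches this phenyl alone. A modest move toward weaker inhibition therefore seems the most reasonable expectation, held with wide uncertainty. The estimate means a 2.2-fold higher number from compound 2 to compound 4 (0.34 log units; beyond the scatter), an expected step of modest size. For compound 4 the expected value is 500 nM, with an estimated range from 70 nM to 3500 nM.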

Compound 4, half-maximal inhibitory concentration: 16 nM
For compound 4 the middle estimate is 31-fold (1.49 log units) above the measured one; measured number outside the range, below it.
By their numbers in this assay, from the lowest: compound 4; then compound 2; then compound 1. At a limit, above all of these: compound 3.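

In this assay, among the compounds shown here, bromo in place of hydrogen on an aromatic carbon of the phenyl gives a 14-fold lower number from compound 2 to compound 4 (1.16 log units; beyond the scatter), so this position, which no earlier single-place step touched, responds strongly to the addition of one heavy atom. For the compounds shown here, the only earlier single-place step lay elsewhere in the molecule and went toward weaker inhibition, whereas this one shows that a single small change can also move the number far toward stronger inhibition. Nothing measured among these compounds explains why bromo has this effect on this phenyl.

On these data alone, it remains open whether the gain belongs to bromo itself or would also come with another group on the same carbon, such as fluoro, methyl or an amine, and whether bromo on a different carbon of this ring would act alike. As far as these compounds go, this is also a single pair of compounds, so it remains open whether the same step would carry over when the other side of the molecule changes.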